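The source may report more compounds than this note shows. Statements on the series, on what has been measured and on what is new or still open speak of the compounds shown alone.

Compound 1 `CCCc1nc(C)c2c(C3CC3)nnc(O)n12` was tested in a functional assay for inhibition, with Homo sapiens as the target; on this read-out lower numbers stand for stronger inhibition and higher numbers for weaker inhibition. In this assay compound 1 gives only a limit, > 48000 nM. Compound 2 `Cc1nc(-c2ccccc2)n2c(O)nncc12` likewise returns only a limit, > 48000 nM. Both values sit at the same point, as the limit of > 48000 nM in this assay, at which 2 of the 2 values shown sit, shows, so compound 1 stands no higher and no lower than the other value shown. Compound 3 `CCCc1nc(C)c2cnnc(O)n12` differs from compound 1 by hydrogen in place of cyclopropyl on an aromatic carbon. Among the measured compounds shown here, with no measured step to draw on, the step that the limit leaves unreadable from compound 1 to compound 3 is expected to be none beyond the scatter. Compound 3 is therefore expected to give 60000 nM, with a range from 20000 nM to 200000 nM, most likely again as a limit.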

Compound 3, half-maximal inhibitory concentration: 56800 nM
Compound 3: the middle estimate sits 1.1-fold (0.02 log units) above what was measured; low and high end bracket the measured number.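

Among the compounds shown here, compound 1 gives only a limit, so no step from compound 1 to compound 3 can be read: the limit of > 48000 nM in this assay, at which 2 of the 3 values shown sit. The compounds shown leave open whether hydrogen in place of cyclopropyl on an aromatic carbon changes inhibition at all.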